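The compounds below may be only part of what the source reports. "The series", "measured", "known", "first", "only" and "open" are said of these compounds alone.

Compound 1 `C[C@H](Nc1ncnc2[nH]cnc12)c1nn(-c2cccnc2)c2cc(Cl)ccc12` gives 13% in a functional assay on HepG2 cells (Homo sapiens) for inhibition, read by sulforhodamine B assay, with a stated time of 72 h, tested at 10 uM; on this read-out lower numbers stand for less inhibition and higher numbers for more inhibition at the one concentration tested (going by the name of the read-out).
Compound 2 `C[C@H](Nc1nc(N)nc2[nH]cnc12)c1nn(-c2cccnc2)c2cc(F)ccc12` gives 11% in this assay.
Compound 3 `C[C@H](Nc1ncnc2[nH]cnc12)c1nn(-c2cccnc2)c2cc(F)ccc12` gives 23% in this assay.

Compound 3 has the largest of the three numbers: the step of a number 10 percentage points higher from compound 1 to compound 3 (within the scatter) and the step of a number 12 percentage points higher from compound 2 to compound 3 (beyond the scatter). Compound 4 `C[C@H](Nc1ncnc2[nH]cnc12)c1nn(-c2ccccn2)c2cc(F)ccc12` differs from compound 3 by pyridin-2-yl in place of pyridin-3-yl on an aromatic nitrogen. Neither measured step concerns the pyridin-3-yl group; one concerns the fluoro or chloro group and the other the amino group on the shared core. Among the compounds with values here, no measured step therefore bears on this change, and the expectation in this assay is a step of no size beyond the scatter, a number 3 percentage points lower from compound 3 to compound 4 (within the scatter). Compound 4 is thus estimated at 20%, with a range from 5% to 40%.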

Compound 4, a percentage reported as inhibition, at one concentration (the size of the read-out at that concentration, not a potency): 22%
Estimate against measurement, compound 4: 2 percentage points below; the measured number falls inside the stated range.
By their numbers in this assay, from the lowest: compounds 2, 1, 4 and 3 (each within the scatter of the next, the first and the last beyond it).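

Pyridin-2-yl in place of pyridin-3-yl on the aromatic nitrogen is the only change shown at this position, and in this assay it gives a number 1 percentage points lower from compound 3 to compound 4 (within the scatter). The earlier steps shown here concerned only the fluoro or chloro group and the amino group, whereas this one shows that the two pyridinyl groups cannot be told apart here on this read-out. Nothing available offers an explanation for this result. The compounds shown leave open whether pyridin-4-yl, plain phenyl or a simple alkyl chain on this nitrogen would give a different number. They also leave open whether a pyridine ring carrying an amine would do so.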